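A Much Larger Group on a Compound at the Limit

This account rests on a few compounds, and the source may have more. Where it says the series, first, only, none or still open, it means among the compounds named here.

Compound 1 `COC(=O)N[C@H](C(=O)NN(CCC[C@@](O)(Cc1ccccc1)C(=O)N[C@H]1c2ccccc2C[C@H]1O)Cc1ccc(F)cc1)C(C)(C)C`: > 10000 nM
Compound 2 `COC(=O)N[C@H](C(=O)NN(CCC[C@@](O)(Cc1ccccc1)C(=O)N[C@H]1c2ccccc2C[C@H]1O)CC(C)C)C(C)(C)C`: > 10000 nM

In an ADME assay on MT4 cells (Homo sapiens) for cytotoxicity (on this read-out lower numbers stand for higher toxicity in this test and higher numbers for lower toxicity in this test), compound 2 gives > 10000 nM, which is a limit and not a number. Compound 1 gives > 10000 nM, also a limit. Compound 3 `COC(=O)N[C@H](C(=O)NN(CCC[C@@](O)(Cc1ccccc1)C(=O)N[C@H]1c2ccccc2C[C@H]1O)Cc1ccc(-c2ccccn2)cc1)C(C)(C)C` has 4-(pyridin-2-yl)phenyl in place of isopropyl on a saturated chain carbon bound to an amine nitrogen. Going by the values given here, the only measured step at this place is a step that the two limits leave unreadable from compound 1 to compound 2, so it offers no size to carry over. With both values at the limit of > 10000 nM in this assay, at which 2 of the 2 values shown sit, no change beyond the scatter is expected in this assay, and a limit is the likeliest result. The estimated step is a step that the limit leaves unreadable from compound 2 to compound 3. Compound 3 is expected near 15000 nM, with an estimated range of 6000 nM to 40000 nM.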

Compound 3, half-maximal cytotoxic concentration: > 10000 nM
Compound 3: only a limit was reported (the forecaster's own chance of this, stated with the estimate: 75%); the middle value lies beyond the limit too.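

In this assay the steps among compound 1, compound 2 and compound 3 cannot be read, because all three values are limits: the limit of > 10000 nM in this assay, at which 3 of the 3 values shown sit.

As far as these compounds go, whether swapping these groups changes cytotoxicity at all, and how far each true value lies past the limit, stays open.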